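The source may hold more compounds than are shown below. What is called first, only, known or untested is meant among the compounds shown, and "the series" means these compounds.

Compounds measured in a functional assay on PANC-1 cells (Homo sapiens) for inhibition, read by MTT assay, with a stated time of 24 h, tested at 10 uM; a lower number here means less inhibition, a higher number more inhibition at the concentration tested (going by the name of the read-out):
compound 1, `COc1cccc(NC(=O)Oc2cc(=O)n(CCCO)c3c2CC(C/C=C(\C)CCC=C(C)C)C(C)(C)C3)c1`: 47%
compound 2, `CC(C)=CCC/C(C)=C/CC1Cc2c(OC(=O)Nc3ccc(F)cc3F)cc(=O)n(CCCO)c2CC1(C)C`: 33.7%

Compound 2 stands lowest of the two numbers in this assay; its nearest neighbour is compound 1, whose value lies higher by a step beyond the scatter, namely a number 13.3 percentage points lower from compound 1 to compound 2 (beyond the scatter) read in reverse. The unmeasured compound 3, `CC(C)=CCC/C(C)=C/CC1Cc2c(OC(=O)Nc3ccc(F)c(F)c3)cc(=O)n(CCCO)c2CC1(C)C`, differs from compound 2 only in the arrangement of the same atoms: 3,4-difluorophenyl in place of 2,4-difluorophenyl on an amide-type nitrogen.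

Within the data shown here, the single measured step, from compound 1 to compound 2, swaps 3-methoxyphenyl for 2,4-difluorophenyl and reads a number 13.3 percentage points lower from compound 1 to compound 2 (beyond the scatter); it changes the substituent itself, not the placement of fluorine within a difluorophenyl, so it bears on the present step only loosely. Among the measured compounds shown here, with no step of this exact kind measured, the expectation is that compound 3 stays close to compound 2, with a step of a number 4.3 percentage points higher from compound 2 to compound 3 (within the scatter) that is expected to lie within the scatter. Compound 3 is therefore estimated at 38%, with a range from 22% to 54%.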

Compound 3, a percentage reported as inhibition, at one concentration (the size of the read-out at that concentration, not a potency): 43.7%
Beside the measured number, compound 3's estimate is 5.7 percentage points below it, and the stated range covers the measured number.
By their numbers in this assay, from the lowest: compounds 2, 3 and 1 (each within the scatter of the next, the first and the last beyond it).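

In this assay the exchange of 2,4-difluorophenyl for 3,4-difluorophenyl on the amide-type nitrogen gives a number 10 percentage points higher from compound 2 to compound 3 (within the scatter) and so, with the same atoms rearranged, the two difluorophenyl groups cannot be told apart in this read-out. The other new step, a number 3.3 percentage points lower from compound 1 to compound 3 (within the scatter), leaves 3,4-difluorophenyl likewise indistinguishable from 3-methoxyphenyl, whereas the earlier step reads a number 13.3 percentage points lower from compound 1 to compound 2 (beyond the scatter) and is the only one of the three printed as beyond the scatter. No measurement available here accounts for these readings.

Among these compounds, whether any arrangement of substituents on this ring matters more than the scatter remains open with only three aryl groups in view. A plain phenyl, a cyclohexyl group or a carboxylic acid on the ring would show whether the inhibition in this assay is higher, lower or level with further changes at this nitrogen.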